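Trimming a Side Chain from a Protected Core

The compounds below may be only part of what the source reports. "The series", "measured", "known", "first", "only" and "open" are said of these compounds alone.

In an ADME assay on RWPE-1 cells (Homo sapiens) for inhibition, read by MTT assay, with a stated time of 24 h (on this read-out higher numbers stand for weaker inhibition and lower numbers for stronger inhibition), compound 1 `C/C=C/C(=O)CC1c2cc(OCc3cc(C)cc(C)c3)c(OCc3cc(C)cc(C)c3)cc2CCN1C(=O)OC(C)(C)C` reaches only a limit of the assay, > 20000 nM. Compound 2 `CCC[C@@H]1C[C@H](O)C/C=C(/CC)[C@H]2c3cc(OCc4ccccc4)c(OCc4ccccc4)cc3CCN12` likewise gives a limit, > 20000 nM. Compound 3 `CCC[C@@H]1CC(=O)C/C=C(/CC)[C@H]2c3cc(OCc4ccccc4)c(OCc4ccccc4)cc3CCN12` also gives a limit, > 20000 nM. Going by the values given here, compound 1 thus stands together with the others at the limit of > 20000 nM in this assay, at which 3 of the 3 values shown sit, so no compound here can be placed above or below another. Compound 4 `Cc1cc(C)cc(COc2cc3c(cc2OCc2cc(C)cc(C)c2)CN(C(=O)OC(C)(C)C)CC3)c1` differs from compound 1 by one change (hydrogen in place of ((prop-1-en-1-yl)carbonyl)methyl on a saturated ring carbon). Among the compounds with values here, no measured pair here differs in only one place, so no step can be read off. Since all three compounds sit at the limit of the assay, the step that the limit leaves unreadable from compound 1 to compound 4 is expected to be none beyond the scatter. Compound 4 is therefore expected to give about 30000 nM, within 10000 nM to 100000 nM, most likely again only a limit.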

Compound 4, half-maximal inhibitory concentration: > 20000 nM
Compound 4 ended at the assay's limit; the forecaster's own chance of this, stated with the estimate: 85%; the middle value lies beyond the limit too.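

Going by these compounds alone, compound 1 and compound 4 both give only a limit, so no step between them can be read. The compounds shown leave open how strongly any of them inhibits, and whether losing the ((prop-1-en-1-yl)carbonyl)methyl group changes anything.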